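This account rests on a few compounds, and the source may have more. Where it says the series, first, only, none or still open, it means among the compounds named here.

Measured so far:
compound 1, `O=C(Nc1ccc(C(=O)NO)cc1)Nc1ccc(Cl)c(C(F)(F)F)c1`, 3100 nM
compound 2, `O=C(/C=C/c1ccc(NC(=O)Nc2ccc(Cl)c(C(F)(F)F)c2)cc1)NO`, 1900 nM
compound 3, `O=C(/C=C/c1ccc(CN2CCc3cc(NC(=O)Nc4ccc(Cl)c(C(F)(F)F)c4)ccc32)cc1)NO`, 2300 nM

All three were tested in a functional assay on PC-3 cells (Homo sapiens) for inhibition, read by sulforhodamine B assay, with a stated time of 48 h; on this read-out higher numbers stand for weaker inhibition and lower numbers for stronger inhibition. Compound 2 and compound 1 differ in one place only: hydroxycarbamoyl in place of 2-(hydroxycarbamoyl)ethenyl on an aromatic carbon. That change gave a 1.6-fold higher number from compound 2 to compound 1 (0.21 log units; within the scatter), so the two values cannot be told apart with confidence. Compound 3 carries a larger core; the difference between its core and that of compound 2 is not broken down here, and their values sit close together.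

Compound 4, `O=C(Nc1ccc2c(c1)CCN2Cc1ccc(C(=O)NO)cc1)Nc1ccc(Cl)c(C(F)(F)F)c1`, has not yet been measured. It relates to compound 3 exactly as compound 1 relates to compound 2: hydroxycarbamoyl in place of 2-(hydroxycarbamoyl)ethenyl on an aromatic carbon. The same change, in the same surroundings, was already seen once, where it moved the number only slightly. For compound 4 the expected step is therefore a 1.5-fold higher number from compound 3 to compound 4 (0.18 log units; within the scatter), resting on the earlier 1.6-fold higher number from compound 2 to compound 1 (0.21 log units; within the scatter), which stayed within the usual scatter. On that basis compound 4 is expected to give about 3500 nM in this assay, likely between 1500 nM and 8000 nM.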

Compound 4, half-maximal inhibitory concentration: 3400 nM
The estimate for compound 4 lay 1.0-fold (0.01 log units) above the measured number; low and high end bracket the measured number.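

In this assay the swap of 2-(hydroxycarbamoyl)ethenyl for hydroxycarbamoyl on the larger core gave a 1.5-fold higher number from compound 3 to compound 4 (0.17 log units; within the scatter), so the number barely moved. Set beside the earlier case, the change looks the same on both cores: the same change on two cores in this assay, a 1.6-fold higher number (0.21 log units; within the scatter) from compound 2 to compound 1 and a 1.5-fold higher number (0.17 log units; within the scatter) from compound 3 to compound 4, 1.1-fold (0.04 log units) apart, within the scatter of two such steps. This shows that, on these two cores, the change carried over without a clear difference in the number, but both steps lie within the scatter, so the data show no real effect of the change, and two cores say nothing about how it would behave on any other core in the series.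

The compounds shown offer only these two groups on that aromatic carbon, so it stays open whether a carboxylic acid in place of hydroxycarbamoyl, or a longer chain such as 3-(hydroxycarbamoyl)propyl, would move the number beyond the scatter. From the compounds shown here alone, it also stays open whether the step would look the same on other cell types.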